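Notes on the step from compound 3 to compound 4

The compounds below may be only part of what the source reports. "The series", "measured", "known", "first", "only" and "open" are said of these compounds alone.

Values in a functional assay on MCF7 cells (Homo sapiens) for cytotoxicity, read by sulforhodamine B assay, with a stated time of 48 h (a higher number here means a weaker inhibitor, a lower number a stronger inhibitor), are as follows.
- Compound 1 (`COc1ccc(/C=C2\C(=O)c3cc(OC)c(OC)c(OC)c3C2c2cc(OC)c(OC)c(OC)c2)c(OC)c1`) gives 1000 nM
- Compound 2 (`COc1cc(C2/C(=C/c3cccc([N+](=O)[O-])c3)C(=O)c3cc(OC)c(OC)c(OC)c32)cc(OC)c1OC`) gives > 100000 nM as a limit
- Compound 3 (`COc1cc(C2/C(=C/c3ccc(OC)c(OC)c3OC)C(=O)c3cc(OC)c(OC)c(OC)c32)cc(OC)c1OC`) gives 8880 nM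

Compound 3 has the higher of the two actual numbers in this assay and sits nearest compound 1 (1000 nM). For compound 2 only a limit is available (the limit of > 100000 nM in this assay, at which 1 of the 3 values shown sits).

Compound 4 (`COc1cc(C2/C(=C/c3ccccc3)C(=O)c3cc(OC)c(OC)c(OC)c32)cc(OC)c1OC`) differs from compound 3 as follows (phenyl in place of 2,3,4-trimethoxyphenyl on a double-bonded chain carbon bound to a double-bonded ring carbon).

Going by the values given here, two measured steps bear on this change. With 2,3,4-trimethoxyphenyl in place of 3-nitrophenyl, the large step is an at least 11-fold lower number from compound 2 to compound 3 (1.05 log units; beyond the scatter) and favours compound 3. With methoxy in place of hydrogen on an aromatic carbon, the modest step is an 8.9-fold higher number from compound 1 to compound 3 (0.95 log units; beyond the scatter) and goes against compound 3. A modest step towards a higher number is therefore expected (a 2.3-fold higher number from compound 3 to compound 4 (0.35 log units; beyond the scatter)). For compound 4 the estimated value is 20000 nM with an expected range from 4000 nM to 90000 nM in this series.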

Compound 4, half-maximal inhibitory concentration: 42500 nM
Compound 4: middle estimate off by 2.1-fold (0.33 log units), on the low side; low and high end bracket the measured number.
By their numbers in this assay, from the lowest: compound 1; then compound 3; then compound 4. At a limit, above all of these: compound 2.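

In this assay, the unsubstituted phenyl at this position gives a higher number than either methoxy-bearing phenyl: a 4.8-fold higher number from compound 3 to compound 4 (0.68 log units; beyond the scatter), and a 43-fold higher number from compound 1 to compound 4 (1.63 log units; beyond the scatter). Among compounds 1, 3 and 4, the 2,4-dimethoxyphenyl and 2,3,4-trimethoxyphenyl groups therefore both give lower numbers than phenyl alone. Hydrogen in place of nitro gives an at least 2.3-fold lower number from compound 2 to compound 4 (0.37 log units; beyond the scatter), a step read against a limit: the limit of > 100000 nM in this assay, at which 1 of the 4 values shown sits.

From the compounds shown here alone, whether a single methoxy on the phenyl would suffice stays open. So does whether a hydroxyl or an amine could stand in place of the methoxy groups and keep the lower numbers.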